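Reversing the Urea Change: An Estimate for Compound 4

The compounds below may be only part of what the source reports. "The series", "measured", "known", "first", "only" and "open" are said of these compounds alone.

Measured in a functional assay on RPMI-8226 cells (Homo sapiens) for inhibition, read by sulforhodamine B assay, with a stated time of 48 h; on this read-out lower numbers stand for stronger inhibition and higher numbers for weaker inhibition:
compound 1, `COc1cc(-c2nn(-c3cccc(NC(=O)c4cccc(C(F)(F)F)c4)c3)cc2-c2ccncc2)ccc1Cl`, gives 1570 nM;
compound 2, `COc1cc(-c2nn(-c3cccc(NC(=O)Nc4ccc(Cl)c(Cl)c4)c3)cc2-c2ccncc2)ccc1Cl`, gives 390 nM;
compound 3, `COc1cc(-c2nn(-c3cccc(NC(=O)Nc4cccc(C(F)(F)F)c4)c3)cc2-c2ccncc2)ccc1Cl`, gives 340 nM.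

Compound 3 has the lowest number of the three, but its gap to compound 2 is within the scatter (a 1.1-fold lower number from compound 2 to compound 3 (0.06 log units; within the scatter)), so the two cannot be ranked. Only compound 1 is clearly apart (a 4.6-fold lower number from compound 1 to compound 3 (0.66 log units; beyond the scatter)).

Compound 4 is `COc1cc(-c2nn(-c3cccc(NC(=O)c4ccc(Cl)c(C(F)(F)F)c4)c3)cc2-c2ccncc2)ccc1Cl`. It differs from compound 3 by 4-chloro-3-(trifluoromethyl)phenyl in place of (3-(trifluoromethyl)phenyl)amino on a carbonyl carbon. This undoes the change that led from compound 1 to compound 3, where an aryl on the carbonyl was exchanged for an arylamino: that step gave a 4.6-fold lower number from compound 1 to compound 3 (0.66 log units; beyond the scatter), and the matching step gave a 4.0-fold lower number from compound 1 to compound 2 (0.60 log units; beyond the scatter). Both moved the number down by a modest amount, so putting an aryl back on the carbonyl is expected to move it up by a similar amount in this assay. Among the compounds with values here, the added chlorine has no measured counterpart here, which widens the range.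

Compound 4 is therefore expected to give 1300 nM, between 500 nM and 3500 nM, an expected 3.8-fold higher number from compound 3 to compound 4 (0.58 log units; beyond the scatter).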

Compound 4, half-maximal inhibitory concentration: 1620 nM
Compound 4: middle estimate off by 1.2-fold (0.10 log units), on the low side; low and high end bracket the measured number.
By their numbers in this assay, from the lowest: compounds 3 and 2 (each within the scatter of the next); then compounds 1 and 4 (each within the scatter of the next).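

In this assay, compound 4 shows that an aryl on the carbonyl carbon again gives a clearly higher number than an arylamino group, even with the new chloro present: a 4.8-fold higher number from compound 3 to compound 4 (0.68 log units; beyond the scatter), and a 4.2-fold higher number from compound 2 to compound 4 (0.62 log units; beyond the scatter). The chloro in place of hydrogen on an aromatic carbon leaves no readable mark in the aryl series: a 1.0-fold higher number from compound 1 to compound 4 (0.01 log units; within the scatter). Across these four compounds, with none going against it, the numbers divide by aryl or arylamino on the carbonyl carbon, and the added chloro does not alter that division.

From the compounds shown here alone, it remains open whether an aryloxy group or a benzylamino group on the carbonyl carbon would fall with the arylamino compounds or with the aryl ones. No measurement shown here reveals what lies behind the divide.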